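Cytotoxicity of Bromo and Methoxy Analogues in Vero Cells

The compounds below may be only part of what the source reports. "The series", "measured", "known", "first", "only" and "open" are said of these compounds alone.

Measured so far:
compound 1 `CC(=O)C[C@H]1O[C@@H](On2cc(CN3C(=O)/C(=N\Nc4ccc(Br)cc4)c4ccccc43)nn2)[C@H](OC(C)=O)[C@@H](OC(C)=O)[C@H]1OC(C)=O`: 83400 nM
compound 2 `COc1ccc(N/N=C2\C(=O)N(Cc3cn(O[C@@H]4O[C@H](CC(C)=O)[C@H](OC(C)=O)[C@H](OC(C)=O)[C@H]4OC(C)=O)nn3)c3ccccc32)cc1`: 62500 nM
compound 3 `CC1(C)O[C@H]2O[C@H](Cn3cc(CN4C(=O)/C(=N\Nc5ccc(Br)cc5)c5ccccc54)nn3)[C@H](O)[C@H]2O1`: 72900 nM

In an ADME assay on Vero cells (Chlorocebus sabaeus) for cytotoxicity, read by fluorescence and resazurin assay, with a stated time of 3 days (on this read-out higher numbers stand for lower toxicity in this test and lower numbers for higher toxicity in this test), compound 1 gives 83400 nM, and compound 2 gives 62500 nM. The difference between them is methoxy in place of bromo on an aromatic carbon, and the step is a 1.3-fold lower number from compound 1 to compound 2 (0.13 log units; within the scatter). Compound 3 gives 72900 nM in this assay; its core differs from that of compound 1, and this difference is not broken down here. Compound 4 `COc1ccc(N/N=C2\C(=O)N(Cc3cn(C[C@H]4O[C@@H]5OC(C)(C)O[C@@H]5[C@H]4O)nn3)c3ccccc32)cc1` has not yet been measured. It differs from compound 3 by methoxy in place of bromo on an aromatic carbon, the same change as that from compound 1 to compound 2. Because that earlier step was a 1.3-fold lower number from compound 1 to compound 2 (0.13 log units; within the scatter), a step of similar size is expected here, namely a 1.3-fold lower number from compound 3 to compound 4 (0.12 log units; within the scatter). Compound 4 is therefore estimated at 55000 nM, with a range from 27000 nM to 110000 nM.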

Compound 4, half-maximal cytotoxic concentration: 74500 nM
The estimate for compound 4 lay 1.4-fold (0.13 log units) below the measured number; the range from low to high includes it.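

Methoxy in place of bromo on an aromatic carbon gives a 1.0-fold higher number from compound 3 to compound 4 (0.01 log units; within the scatter) in this assay. Set beside the earlier step, the same change reads alike on the two cores: the same change on two cores in this assay, a 1.3-fold lower number (0.13 log units; within the scatter) from compound 1 to compound 2 and a 1.0-fold higher number (0.01 log units; within the scatter) from compound 3 to compound 4, 1.4-fold (0.13 log units) apart, within the scatter of two such steps. Going by these compounds alone, this shows that on these two cores the change stays within the scatter and that its size carries from one core to the other, but it rests on only two pairs and does not show that the same would hold on any other core or in any other test.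

The compounds shown leave open how an amine, a carboxylic acid or a longer alkoxy chain would read on the same aromatic carbon. They also leave open whether any such group would move the number beyond the scatter.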